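A few compounds are considered here, and "the series" means these few. Any claim that something is new, unique, unknown or untested is made for them only; others in the source may bear on it.

Measured compounds:
compound 1 `CCOc1ccc(-n2c(S)nnc2CSc2nnc(-c3ccccc3)n2-c2ccccc2)cc1` — "not determined" (no result reported) in a functional assay on HT-29 cells (Homo sapiens) for inhibition, read by MTT assay, with a stated time of 48 h; on this read-out higher numbers stand for weaker inhibition and lower numbers for stronger inhibition
compound 2 `Fc1ccc(-n2c(S)nnc2Sc2nnc(-c3ccccc3)n2-c2ccccc2)cc1` — 32800 nM

Compound 1 has no number in this assay; the one measured point in the series is compound 2, which in this assay gives 32800 nM. Compound 3 `COc1ccc(-n2c(S)nnc2CSc2nnc(-c3ccccc3)n2-c2ccccc2)cc1` follows from compound 1 by hydrogen in place of methyl on a saturated chain carbon bound to an oxygen on an aromatic ring. For the measured compounds named here, no step between measured compounds covers this change, so its size in this assay cannot be read from the data; with a single weak measured point nearby, no shift beyond the scatter is assumed in either direction. Compound 3 is expected to give about 30000 nM in this assay, within 8000 nM to 100000 nM.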

Compound 3, half-maximal inhibitory concentration: 27700 nM
Beside the measured number, compound 3's estimate is 1.1-fold (0.03 log units) above it; the measured number falls inside the stated range.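

In this assay no new step can be read from compound 1 to compound 3, since compound 1 has no single number there. From the compounds shown here alone, what ethoxy to methoxy does to inhibition stays open. No further data bear on this result.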